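This account rests on a few compounds, and the source may have more. Where it says the series, first, only, none or still open, it means among the compounds named here.

Among the compounds with values here, compound 3 `CN(C)CCCn1c(N)c(-c2nc3cc(Cl)ccc3[nH]2)c2nc(C#N)c(C#N)nc21` gives 28100 nM in a functional assay on cells (Homo sapiens) for antiproliferative activity, read by MTT assay, with a stated time of 48 h (on this read-out higher numbers stand for weaker inhibition and lower numbers for stronger inhibition), the higher of the two actual numbers so far. Compound 1 `CN(C)CCCCn1c(N)c(-c2nc3ccccc3o2)c2nc(C#N)c(C#N)nc21` gives 6130 nM, a gap beyond the scatter. Compound 2 `CN(C)CCn1c(N)c(-c2nc3cc(Cl)ccc3[nH]2)c2nc(C#N)c(C#N)nc21` gives > 50000 nM, which is a limit and not a number. Compound 4 `CN(C)CCCCn1c(N)c(-c2nc3cc(Cl)ccc3[nH]2)c2nc(C#N)c(C#N)nc21` carries (dimethylamino)methyl in place of dimethylamino on a saturated chain carbon, three bonds along the chain from an aromatic nitrogen; the change reads 3-(dimethylamino)propyl to 4-(dimethylamino)butyl. Within the data shown here, the one measured step bearing on it is an at least 1.7-fold lower number from compound 2 to compound 3 (0.25 log units; that floor lies within the scatter), the same change made two bonds along the chain from an aromatic nitrogen. A small further fall in the number is therefore expected in this assay, not clearly beyond the scatter, with the estimated step being a 1.8-fold lower number from compound 3 to compound 4 (0.24 log units; within the scatter). The estimate for compound 4 is 16000 nM, expected within 6000 nM to 40000 nM.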

Compound 4, half-maximal inhibitory concentration: 3280 nM
Compound 4: the middle estimate sits 4.9-fold (0.69 log units) above what was measured, and the stated range ends above it.
By their numbers in this assay, from the lowest: compounds 4 and 1 (each within the scatter of the next); then compound 3. At a limit, above all of these: compound 2.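

In this assay, going from 3-(dimethylamino)propyl to 4-(dimethylamino)butyl gives an 8.6-fold lower number from compound 3 to compound 4 (0.93 log units; beyond the scatter), so chain length now has a clear effect at this position, which the earlier step along the chain did not establish. The wider step, an at least 15-fold lower number from compound 2 to compound 4 (1.18 log units; beyond the scatter), is only a floor, its starting value being a limit and not a number: the limit of > 50000 nM in this assay, at which 1 of the 4 values shown sits. With the 4-(dimethylamino)butyl chain held, 5-chloro-1H-benzimidazol-2-yl in place of 1,3-benzoxazol-2-yl gives a 1.9-fold lower number from compound 1 to compound 4 (0.27 log units; within the scatter), so that swap shows no clear change.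

From the compounds shown here alone, whether a longer chain such as 5-(dimethylamino)pentyl lowers the number further remains open. So does whether a pyrrolidine in place of the dimethylamino group keeps this level.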